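This account rests on a few compounds, and the source may have more. Where it says the series, first, only, none or still open, it means among the compounds named here.

Working notes on the series, with all values from an ADME assay on microsomes from liver (Homo sapiens) for metabolic stability, using NADPH, with a stated time of 40 min, tested at 2 uM; on this read-out higher numbers stand for a longer-lived compound and lower numbers for a shorter-lived compound. Compound 1 (`Cc1cccc2c(-c3ccc4cccc(F)c4n3)c[nH]c12`) gives 0.983 h and compound 2 (`CNC(=O)c1cccc2nc(-c3c[nH]c4c(C)cccc34)ccc12`) gives 0.983 h. Compound 2 therefore stands level with compound 1, and together they hold the highest of the three numbers. Compound 3 (`Fc1ccc2c(-c3ccc4ccccc4n3)c[nH]c2c1F`) gives 0.167 h, which lies beyond the scatter from compound 2.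

Compound 4 (`Cc1cccc2c(-c3ccc4ccccc4n3)c[nH]c12`) follows from compound 2 by one change, hydrogen in place of methylcarbamoyl on an aromatic carbon. Within the data shown here, no two measured compounds differ in one place only, so this assay offers no direct precedent for this change. Among the measured compounds shown here, the only guide is the spread of the measured values, from compound 3 at 0.167 h to compound 1 at 0.983 h.

A modest fall is expected, roughly at the edge of the scatter, and the estimated change is a 2.2-fold lower number from compound 2 to compound 4 (0.34 log units; beyond the scatter). Compound 4 is estimated at 0.45 h, with an expected range of 0.17 h to 1 h.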

Compound 4, half-life: 0.35 h
Compound 4: middle estimate off by 1.3-fold (0.11 log units), on the high side; the measured number falls inside the stated range.
By their numbers in this assay, from the lowest: compound 3; then compound 4; then compounds 1 and 2 (each within the scatter of the next).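

Compound 4 gives the series its first steps in one place, and both are beyond the scatter. On the aromatic carbon, hydrogen in place of methylcarbamoyl gives a 2.8-fold lower number from compound 2 to compound 4 (0.45 log units; beyond the scatter) in this assay, so the number here is higher with the methylcarbamoyl group than without it, while hydrogen in place of fluoro gives a 2.8-fold lower number from compound 1 to compound 4 (0.45 log units; beyond the scatter), a step of the same printed size. Nothing available here bears on the reason for either step.

Going by these compounds, whether a primary carboxamide, a carboxylic acid or an amine on this aromatic carbon would hold the number of compound 2 stays open, as does whether chloro could stand in for the fluoro of compound 1. Also open, on these data alone, is what methylcarbamoyl and fluoro would give together on the shared core.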